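Three quinone ethers and esters and a fourth awaiting measurement

The source may hold more compounds than are shown below. What is called first, only, known or untested is meant among the compounds shown, and "the series" means these compounds.

Compound 1 `COC(C)CO[C@H](CC=C(C)C)C1=CC(=O)c2c(O)ccc(O)c2C1=O` gives 53400 nM in a functional assay on HeLa cells (Homo sapiens) for cytotoxicity, read by MTT assay; on this read-out higher numbers stand for weaker inhibition and lower numbers for stronger inhibition. Compound 2 `CC[C@](C)(O)CC(=O)O[C@H](CC=C(C)C)C1=CC(=O)c2c(O)ccc(O)c2C1=O` gives 30200 nM. Compound 3 `CC(C)=CC[C@@H](OC(=O)CCO)C1=CC(=O)c2c(O)ccc(O)c2C1=O` gives 67600 nM.

Compound 1 stands second highest of the three numbers; its steps to compound 2 and compound 3 are a 1.8-fold lower number from compound 1 to compound 2 (0.25 log units; within the scatter) and a 1.3-fold higher number from compound 1 to compound 3 (0.10 log units; within the scatter), both within the scatter. Compound 4 `CC(C)=CC[C@@H](OCC(C)O)C1=CC(=O)c2c(O)ccc(O)c2C1=O` differs from compound 1 by hydrogen in place of methyl on an oxygen on a saturated carbon. For the measured compounds named here, no measured step repeats this change: the steps from compound 1 replace the whole 2-methoxypropyl group, and the step of a 2.2-fold higher number from compound 2 to compound 3 (0.35 log units; beyond the scatter) alters a chain within an ester. With all three numbers close together, compound 4 is expected to show no step beyond the scatter, a 1.1-fold lower number from compound 1 to compound 4 (0.03 log units; within the scatter). The estimate for compound 4 is 50000 nM, ranging from 25000 nM to 100000 nM.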

Compound 4, half-maximal inhibitory concentration: 24700 nM
Compound 4: middle estimate off by 2.0-fold (0.31 log units), on the high side; the measured number lies below the stated range.
By their numbers in this assay, from the lowest: compounds 4, 2, 1 and 3 (each within the scatter of the next, the first and the last beyond it).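

In this assay, hydrogen in place of methyl on this oxygen, a change of one carbon, moves the number beyond the scatter (a 2.2-fold lower number from compound 1 to compound 4 (0.33 log units; beyond the scatter)). Setting 2-hydroxypropyl in place of an ester group goes beyond the scatter in one case (a 2.7-fold lower number from compound 3 to compound 4 (0.44 log units; beyond the scatter)) and stays within it in the other (a 1.2-fold lower number from compound 2 to compound 4 (0.09 log units; within the scatter)). No evidence at hand bears on the reason for these steps.

Going by these compounds, how an amine in place of the hydroxy of the 2-hydroxypropyl group would read stays open. So does the reading of a longer chain carrying that hydroxy.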